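This account rests on a few compounds, and the source may have more. Where it says the series, first, only, none or still open, it means among the compounds named here.

Working notes on the series. Compound 1 `CC(C)[C@H](NC(=O)COc1cccc2ccccc12)C(=O)N[C@@H](CC(=O)O)C(=O)COc1cc(C(F)(F)F)n(C)n1` sets the shared core, and in a functional assay on Jurkat cells (Homo sapiens) for inhibition (on this read-out higher numbers stand for weaker inhibition and lower numbers for stronger inhibition), compound 1 gives 46000 nM. Compound 2 `CC(C)[C@H](NC(=O)COc1cccc2ccccc12)C(=O)N[C@@H](CC(=O)O)C(=O)CSc1ncc[nH]1` carries (1H-imidazol-2-yl)sulfanyl instead; for compound 2 this assay reports only the limit > 200000 nM. Compound 3 `CC(C)[C@H](NC(=O)COc1cccc2ccccc12)C(=O)N[C@@H](CC(=O)O)C(=O)CSc1nc(-c2ccccc2)no1` carries (3-phenyl-1,2,4-oxadiazol-5-yl)sulfanyl, and in this assay compound 3 gives 102000 nM, the highest of the two numbers, reached by a 2.2-fold higher number from compound 1 to compound 3 (0.35 log units; beyond the scatter), while the other step reads an at least 1.9-fold lower number from compound 2 to compound 3 (0.29 log units; that floor lies within the scatter). Compound 4 `CC(C)[C@H](NC(=O)COc1cccc2ccccc12)C(=O)N[C@@H](CC(=O)O)C(=O)CSc1nnnn1C` differs from compound 3 by 1-methyl-1H-tetrazol-5-yl in place of 3-phenyl-1,2,4-oxadiazol-5-yl on a sulfur. The step that bears on this exchange of one heteroaryl on the sulfur for another is an at least 1.9-fold lower number from compound 2 to compound 3 (0.29 log units; that floor lies within the scatter), which points the other way and is not beyond the scatter; the expected outcome for compound 4 is a 1.5-fold higher number from compound 3 to compound 4 (0.17 log units; within the scatter). Compound 4 is estimated at 150000 nM, within 60000 nM to 400000 nM.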

Compound 4, half-maximal inhibitory concentration: > 200000 nM
Compound 4 ended at the assay's limit (the forecaster's own chance of this, stated with the estimate: 35%); middle value at least 1.3-fold (0.12 log units) from the limit.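

In this assay compound 4, like compound 2, gives only a limit and not a number: the limit of > 200000 nM in this assay, at which 2 of the 4 values shown sit. The change from the pyrazolyloxy group to (1-methyl-1H-tetrazol-5-yl)sulfanyl reads an at least 4.3-fold higher number from compound 1 to compound 4 (0.63 log units; beyond the scatter), so the three sulfanyl compounds shown, compound 2, compound 3 and compound 4, all give weaker inhibition than compound 1. The exchange on the sulfur reads an at least 1.9-fold higher number from compound 3 to compound 4 (0.29 log units; that floor lies within the scatter), which does not separate compound 4 from compound 3, and the step between the two limits cannot be read.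

On these data alone, it remains open whether the sulfur or the heteroaryl accounts for the difference from compound 1. A (1-methyl-5-(trifluoromethyl)-1H-pyrazol-3-yl)sulfanyl group would separate the two.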